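The source may hold more compounds than are shown below. What is called first, only, known or untested is meant among the compounds shown, and "the series" means these compounds.

Compound 1 `O=C(NO)c1ccc(N(Cc2ccc(C3CCCCC3)cc2)C(=O)[C@H]2CCN2S(=O)(=O)c2c(F)c(F)c(F)c(F)c2F)cc1O` is measured in a functional assay on MDA-MB-231 cells (Homo sapiens) for antiproliferative activity, with a stated time of 72 h (a lower number here means that less compound is needed, a higher number that more compound is needed for the effect), where compound 1 gives 5100 nM. Compound 2 `O=C(NO)c1ccc(N(Cc2ccc(C3CCCCC3)cn2)C(=O)[C@H]2CCN2S(=O)(=O)c2c(F)c(F)c(F)c(F)c2F)cc1O`, which shares most of this structure, has no single number there: in this assay compound 2 stands as "not determined" (no result reported). Compound 3 `CNC(=O)c1ccc(N(Cc2ccc(C3CCCCC3)cn2)C(=O)[C@H]2CCN2S(=O)(=O)c2c(F)c(F)c(F)c(F)c2F)cc1O` differs from compound 2 by a single small exchange: methyl in place of hydroxy on an amide-type nitrogen. Going by the values given here, with no measured step to lean on, and only the value of compound 1 as a rough anchor, the expectation for compound 3 is a large move towards needing more compound rather than a change within the scatter. Compound 3 is therefore expected to give about 30000 nM, with a plausible span from 5000 nM to 200000 nM.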

Compound 3, half-maximal effective concentration: 1800 nM
Compound 3: the middle estimate sits 17-fold (1.22 log units) above what was measured, and the stated range ends above it.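

Going by these compounds alone, compound 2 has no single number, so no step from it to compound 3 can be read. What the exchange of hydroxy for methyl does therefore stays open, and nothing shown bears on the result of compound 3.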